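Removing a Prenyl Chain from a Limit-Bound Analogue

The compounds below may be only part of what the source reports. "The series", "measured", "known", "first", "only" and "open" are said of these compounds alone.

compound 1 `CC(C)=CCC/C(C)=C/C[C@]12C[C@@H](CC=C(C)C)C(C)(C)[C@](CC=C(C)C)(C(=O)CC1=O)C2=O` — 5.6 ug/mL
compound 2 `CC(C)=CC[C@@H]1C[C@]2(CC=C(C)C)C(=O)[C@@](CC=C(C)C)(C(=O)C(C(=O)c3ccccc3)=C2O)C1(C)C` — 12 ug/mL
compound 3 `CC(C)=CCC/C(C)=C/C[C@@H]1C[C@@]2(C/C=C(\C)CCC=C(C)C)C(=O)CC(=O)[C@](CC=C(C)C)(C2=O)C1(C)C` — > 20 ug/mL

In a functional assay on SGC-7901 cells (Homo sapiens) for inhibition (on this read-out higher numbers stand for weaker inhibition and lower numbers for stronger inhibition), compound 1 gives 5.6 ug/mL and compound 2 gives 12 ug/mL. For compound 3 the result in this assay is only a limit, > 20 ug/mL. That is the limit of > 20 ug/mL in this assay, at which 1 of the 3 values shown sits, so compound 3 stands at the weak end of the three measured compounds without a fixed number. Compound 4 `CC(C)=CCC/C(C)=C/C[C@@H]1C[C@@]2(CC=C(C)C)C(=O)CC(=O)[C@](CC=C(C)C)(C2=O)C1(C)C` differs from compound 3 by hydrogen in place of 3-methylbut-2-en-1-yl on a saturated chain carbon bound to a double-bonded chain carbon. One measured step covers this same place in the opposite direction: an at least 3.5-fold higher number from compound 1 to compound 3 (0.55 log units; beyond the scatter). Undoing that change is therefore expected to move the number downward by a comparable amount, an at least 2.5-fold lower number from compound 3 to compound 4 (0.39 log units; beyond the scatter). Compound 4 is estimated at 8 ug/mL, with a range from 3 ug/mL to 20 ug/mL.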

Compound 4, half-maximal inhibitory concentration: 6.89 ug/mL
Beside the measured number, compound 4's estimate is 1.2-fold (0.06 log units) above it, and the stated range covers the measured number.
By their numbers in this assay, from the lowest: compounds 1, 4 and 2 (each within the scatter of the next, the first and the last beyond it). At a limit, above all of these: compound 3.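

this assay reads an at least 2.9-fold lower number from compound 3 to compound 4 (0.46 log units; beyond the scatter), so taking 3-methylbut-2-en-1-yl off at this place gives a fixed number where compound 3 had none. Cut one bond further out, 3,7-dimethylocta-2,6-dien-1-yl gives way to 3-methylbut-2-en-1-yl, and this pair agrees in direction with the earlier one, though both rest on compound 3. The full size of the step stays unknown because compound 3 is only a limit: the limit of > 20 ug/mL in this assay, at which 1 of the 4 values shown sits.

On these data alone, what an amine, a carboxylic acid or a simple methyl would do at this place stays open.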